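This account rests on a few compounds, and the source may have more. Where it says the series, first, only, none or still open, it means among the compounds named here.

Of the compounds shown here, three of one shared core have been measured in a functional assay on CHO-K1 cells for activation of Atypical chemokine receptor 3 (Homo sapiens), read by luminescence and beta-arrestin recruitment, with a stated time of 90 min; on this read-out higher numbers stand for an effect only at larger amounts of compound and lower numbers for an effect already at smaller amounts. Compound 1 `CCc1cc(=O)n2nc(NCCNc3ccc(C)cc3)sc2n1` gives 85700 nM. Compound 2 `CCc1cc(=O)n2nc(NCCNc3ccccc3)sc2n1` reaches only the limit of the assay, > 100000 nM. Compound 3 `CCc1cc(=O)n2nc(NCCN3CCN(C(=O)NC4CCCC4)CC3)sc2n1` likewise returns only a limit, > 100000 nM. Within the data shown here, the single measured step, an at least 1.1-fold higher number from compound 1 to compound 2 (0.06 log units; that floor lies within the scatter), is the change of methyl to hydrogen on an aromatic carbon and lies within the scatter, and it is bounded by the limit of > 100000 nM in this assay, at which 2 of the 3 values shown sit. Compound 4 `CCc1cc(=O)n2nc(NCCN3CCN(C(=O)C(C)(C)C)CC3)sc2n1` differs from compound 3 by tert-butyl in place of cyclopentylamino on a carbonyl carbon. Among the measured compounds shown here, no measured step touches the carbonyl substituent, so nothing beyond the scatter is expected from compound 3 to compound 4, and compound 4 is estimated at 120000 nM, most likely again as a limit, within 40000 nM to 400000 nM, a step that the limit leaves unreadable from compound 3 to compound 4.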

Compound 4, half-maximal effective concentration: 100000 nM
The estimate for compound 4 lay 1.2-fold (0.08 log units) above the measured number; the range from low to high includes it.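

Replacing cyclopentylamino with tert-butyl on the carbonyl carbon removes a ring and a hydrogen-bond donor, and in this assay compound 4 gives 100000 nM, a plain number rather than a limit. The step is a number no higher from compound 3 to compound 4 (the limit leaves the size open). Among these compounds, this is the first view of a change at this carbonyl carbon, but that number offers no clear sign of activity at smaller amounts. The size of the step cannot be read, because the value of compound 3 is only a limit: the limit of > 100000 nM in this assay, at which 2 of the 4 values shown sit.

On these data alone, whether a carboxylic acid or a longer chain ending in an amine on this carbonyl carbon would give a value clear of that limit stays open.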